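This account rests on a few compounds, and the source may have more. Where it says the series, first, only, none or still open, it means among the compounds named here.

Three compounds in an ADME assay on PC-3 cells (Homo sapiens) for cytotoxicity, read by WST assay, tested at 100 uM (a higher number here means more inhibition at the concentration tested (going by the name of the read-out), a lower number less inhibition), share one core and set the ground for this account. Compound 1 `CC(C)(C)OC(=O)c1cccc(NC(=O)C2CCCN(C(=O)c3cc(C(F)(F)F)cc(C(F)(F)F)c3)C2)c1` gives 0% in this assay. Within the data shown here, compound 3 `Cc1nc(-c2cccc(NC(=O)C3CCCN(C(=O)c4cc(C(F)(F)F)cc(C(F)(F)F)c4)C3)c2)cs1` gives 1% in this assay; the one measured step, a number 1 percentage points higher from compound 1 to compound 3 (within the scatter), puts 2-methyl-1,3-thiazol-4-yl in place of tert-butoxycarbonyl on an aromatic carbon. Compound 2 `CC(C)(C)CC(=O)Nc1cccc(C(=O)N2CCCC(C(=O)Nc3ccc(Cl)cc3)C2)c1` gives 0% in this assay, level with compound 1 at the digits shown, and its value and that of compound 3 lie within the scatter of each other. Compound 4 `O=C(Nc1ccc(Cl)cc1)C1CCCN(C(=O)c2cccc(-c3ccco3)c2)C1` has not yet been measured; it differs from compound 2 by furan-2-yl in place of (neopentylcarbonyl)amino on an aromatic carbon. Among the measured compounds shown here, no measured step exchanges these two groups, so the only guide is that the single measured change left the read-out unchanged within the scatter, and all three values sit at the bottom of the scale. Compound 4 is therefore expected to show a number 1 percentage points higher from compound 2 to compound 4 (within the scatter), no step beyond the scatter. The estimate for compound 4 is 1%, expected to fall between -6% and 10%.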

Compound 4, a percentage reported as inhibition, at one concentration (the size of the read-out at that concentration, not a potency): 0%
For compound 4 the middle estimate is 1 percentage points above the measured one; the range from low to high includes it.
By their numbers in this assay, from the lowest: compounds 1, 2, 4 and 3 (each within the scatter of the next).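

In this assay the new step gives no change at the digits printed from compound 2 to compound 4 (within the scatter), with furan-2-yl in place of (neopentylcarbonyl)amino on an aromatic carbon, meta to a large group. At this position, therefore, a chain with no ring and 1 hydrogen-bond donor can give way to a five-membered aromatic ring with 0 hydrogen-bond donors without the read-out leaving the bottom of the scale, a change of group that the earlier step, made on the other side of the shared core, did not cover. Nothing measured here speaks to why the number stays put.

With every value at the bottom of the scale, the compounds shown do not tell these groups apart. On these data alone, whether a primary amine or a carboxylic acid at this position would move the number beyond the scatter remains open.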